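Working notes on a small antiproliferative series

The source may report more compounds than this note shows. Statements on the series, on what has been measured and on what is new or still open speak of the compounds shown alone.

Two compounds carry measurements in a functional assay on HeLa cells (Homo sapiens) for antiproliferative activity, read by MTT assay, with a stated time of 72 h; on this read-out lower numbers stand for stronger inhibition and higher numbers for weaker inhibition. Compound 1 `COc1cc(-n2ncnc2-c2cccc(Cl)c2)cc(OC)c1OC` reports only a limit in this assay, namely > 10000 nM, so no number stands for it. Compound 2 `CCOc1ccc(-c2ncnn2-c2cc(OC)c(OC)c(OC)c2)cc1` gives 15 nM in this assay, the only number shown across the pair. For compound 1 the remaining entry is the limit of > 10000 nM in this assay, at which 1 of the 2 values shown sits. For the measured compounds named here, no step between measured compounds is available, since compounds 1 and 2 differ in more than one place; all that can be said of them is what the two values show, a limit for compound 1 and a number for compound 2.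

Compound 3 `COc1cc(-n2ncnc2-c2ccc(SC)cc2)cc(OC)c1OC` is not yet measured in this assay. It differs from compound 2 by methylsulfanyl in place of ethoxy on an aromatic carbon, the new group sitting on a six-membered aromatic ring of carbon only, para to a large group. Going by the values given here, with no measured step to lean on, the expected change is a 1.7-fold higher number from compound 2 to compound 3 (0.22 log units; within the scatter), a step estimated to stay within the scatter. Compound 3 is accordingly estimated at 25 nM in this assay, with a range from 6 nM to 100 nM.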

Compound 3, half-maximal inhibitory concentration: 150 nM
The estimate for compound 3 lay 6.0-fold (0.78 log units) below the measured number; the whole stated range lies below it.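

For the compounds shown here, compound 3 supplies the first measured single-place steps, and both lie beyond the scatter. On an aromatic carbon para to a large group, methylsulfanyl in place of ethoxy gives in this assay a 10-fold higher number from compound 2 to compound 3 (1.00 log units; beyond the scatter), so this position does not treat the two groups as equivalent, even though compound 3 keeps a number well within the measurable range. On the other side, 4-(methylsulfanyl)phenyl in place of 3-chlorophenyl gives an at least 66-fold lower number from compound 1 to compound 3 (1.82 log units; beyond the scatter), which places compound 3 between the other two and shows that the choice of aromatic substituent alone can separate compounds widely, though for compound 1 the size of this step is only a bound set by a limit: the limit of > 10000 nM in this assay, at which 1 of the 3 values shown sits.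

The compounds shown do not separate the effect of the sulfur atom from that of the chain length, since neither methoxy nor ethylsulfanyl appears at this position. On these data alone, how an amine or a longer chain such as butoxy would read at the same carbon remains open, as does whether the 3-chlorophenyl group would keep its standing with any other change to the core.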